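This account rests on a few compounds, and the source may have more. Where it says the series, first, only, none or still open, it means among the compounds named here.

Compound 1 `COc1cc(/C=N/NC(=O)OCc2ccccc2)cc(OC)c1O` and compound 2 `COc1cc(/C=N/NC(=O)OCc2ccccc2)cc(O)c1O` share one core and differ in a single group on the aromatic ring. In a physicochemical assay on cells (Homo sapiens), with a stated time of 18 h, tested at 1 uM (a higher number here means a weaker effect of the compound at the concentration tested, a lower number a stronger effect), compound 1 gives 38%, while compound 2 gives 17%. The step between them, a number 21 percentage points lower from compound 1 to compound 2 (beyond the scatter), shows that swapping a methoxy for a hydroxy strengthened the effect. Among the compounds with values here, compound 2 therefore stands lowest of the two numbers known so far, with compound 1 as its only neighbour, a clear gap above it.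

Compound 3 `COc1cc(/C=N/NC(=O)OCc2ccccc2)ccc1O` is the next step from compound 2. The change is hydrogen in place of hydroxy on an aromatic carbon; the hydroxy that leaves sits on an aromatic carbon, ortho to a hydroxy group and meta to a methoxy group. Within the data shown here, the only measured step, a number 21 percentage points lower from compound 1 to compound 2 (beyond the scatter), bears on this indirectly: there a methyl came off an oxygen and the effect grew, whereas here an entire hydroxy disappears, leaving a ring with one hydroxy and one methoxy, as in compound 1. Losing a hydroxy is therefore expected to move the number upward, roughly undoing the earlier gain. Compound 3 is expected to give 40% in this assay, between 20% and 65%, an estimated step of a number 23 percentage points higher from compound 2 to compound 3 (beyond the scatter).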

Compound 3, a percentage reported as activity, at one concentration (the size of the read-out at that concentration, not a potency): 75%
Compound 3: middle estimate off by 35 percentage points, on the low side; the measured number lies above the stated range.
By their numbers in this assay, from the lowest: compound 2; then compound 1; then compound 3.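

The place on the ring that holds a hydroxy group in compound 2 and a methoxy group in compound 1 turns out to matter more than the swap between those two groups did: in this assay, leaving only hydrogen there gives a number 58 percentage points higher from compound 2 to compound 3 (beyond the scatter), and the same loss starting from the methoxy group gives a number 37 percentage points higher from compound 1 to compound 3 (beyond the scatter). Both steps point the same way, so among these three compounds the effect is strongest with hydroxy at this place, weaker with methoxy and weakest with hydrogen, and the methoxy group keeps a good part of what the hydroxy group provides rather than counting as a simple loss. Nothing given here explains why this place responds so strongly. On these data alone, the three compounds cover only hydrogen and two groups joined through oxygen, so it remains open whether the oxygen itself is what counts, which an amine, a fluorine atom or a longer chain such as ethoxy at this place could help to settle. As far as these compounds go, how the methoxy group on the other side of the ring and the benzyl end of the molecule contribute also remains open.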